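This account rests on a few compounds, and the source may have more. Where it says the series, first, only, none or still open, it means among the compounds named here.

In an ADME assay (liver) for metabolic stability, with Liver microsome (Homo sapiens) as the target, using microsomes (on this read-out higher numbers stand for fast clearance and lower numbers for slow clearance), compound 1 `Cc1cnc(NC(=O)c2cc(Oc3cnc(C(=O)N(C)C)nc3)c3cc(C)oc3c2)cn1` gives < 8 mL/min/kg as a limit of the assay and not a number. Compound 2 `Cc1cnc(NC(=O)c2cc(Oc3cnc(C(=O)N4CCCCC4)cn3)c3cc(C)oc3c2)cn1` gives 18.2 mL/min/kg as a measured number. Compound 3 `Cc1cc2c(Oc3cnc(C(=O)N4CC(C)C4)cn3)cc(C(=O)Nc3cnccn3)cc2o1` gives < 9.6 mL/min/kg as a limit of the assay, so its standing is known only as a limit and not as a number. Compound 4 `COC1CN(C(=O)c2cnc(Oc3cc(C(=O)Nc4cnccn4)cc4oc(C)cc34)cn2)C1` has not yet been measured and differs from compound 3 in one place (methoxy in place of methyl on a saturated ring carbon), with methoxy in place of methyl on a saturated ring carbon, so that 3-methylazetidin-1-yl becomes 3-methoxyazetidin-1-yl. Among the measured compounds shown here, no two measured compounds differ in one place alone, so the expectation rests on compound 3, whose limit of < 9.6 mL/min/kg is the only anchor. The expected step that the limit leaves unreadable from compound 3 to compound 4 in this assay is none beyond the scatter, with no firm direction. Compound 4 is expected at 9 mL/min/kg with an estimated range from 5 mL/min/kg to 16 mL/min/kg on this read-out.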

Compound 4, clearance: < 9.2 mL/min/kg
Compound 4: only a limit was reported; the forecaster's own chance of this, stated with the estimate: 55%; the middle value is on the limit's open side.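

In this assay, among the compounds shown here, compound 3 and compound 4 are each reported only as a limit of the assay and not as a number, so no step between them can be read. The compounds shown leave open whether 3-methylazetidin-1-yl and 3-methoxyazetidin-1-yl differ at all in clearance.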